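The source may hold more compounds than are shown below. What is called first, only, known or untested is meant among the compounds shown, and "the series" means these compounds.

Going by the values given here, in a functional assay on HL-60 cells (Homo sapiens) for cytotoxicity, read by luminescence and CellTiter-Glo, with a stated time of 3 days (on this read-out higher numbers stand for weaker inhibition and lower numbers for stronger inhibition), compound 1 (`N#Cc1ccc(NC(=O)c2ccc3ccccc3c2O)cc1`) gives 3410 nM, the higher of the two numbers so far, while compound 2 (`O=C(Nc1ccc(C(F)(F)F)cc1)c1cc(F)ccc1O`) gives 490 nM, lower beyond the scatter. Compound 3 (`N#Cc1ccc(NC(=O)c2ccc3ccccc3c2)cc1`) has hydrogen in place of hydroxy on an aromatic carbon of compound 1: hydrogen in place of hydroxy on an aromatic carbon. Among the compounds with values here, no measured pair shows this change, and no compound without a hydroxy has a value yet. In this assay a moderate step to a higher number, beyond the scatter, is expected. The estimated change is a 2.9-fold higher number from compound 1 to compound 3 (0.47 log units; beyond the scatter). For compound 3 the estimate is 10000 nM, with an expected range of 3000 nM to 35000 nM.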

Compound 3, half-maximal inhibitory concentration: > 10000 nM
Compound 3: only a limit was reported; the forecaster's own chance of this, stated with the estimate: 30%; the middle value lies on the limit itself.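

Hydrogen in place of hydroxy gives an at least 2.9-fold higher number from compound 1 to compound 3 (0.46 log units; beyond the scatter) in this assay and is the first step at this position, showing that the hydroxy on the core of compound 1 cannot be lost without a move to a higher number. The value of compound 3 is a limit and not a number, so this step has only a lower bound: the limit of > 10000 nM in this assay, at which 1 of the 3 values shown sits.

Going by these compounds, whether an amine or a methoxy at this position would hold the number of compound 1 remains open. Also open, on these data alone, is whether the same change on compound 2 gives a comparable step.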